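A Five-Membered Ring Replaces the Aryl on the Chain

The source may hold more compounds than are shown below. What is called first, only, known or untested is meant among the compounds shown, and "the series" means these compounds.

Of the compounds shown here, three with a shared core have been tested in an ADME assay on the whole organism for cytotoxicity, with Artemia salina as the target, with a stated time of 24 h; a lower number here means that less compound is needed, a higher number that more compound is needed for the effect. Compound 1 `Cc1ccc(S(=O)(=O)NC(=O)Nc2ccccc2C(=O)/C=C/c2ccccc2)cc1` gives 25 ug/mL. Compound 2 `Cc1ccc(S(=O)(=O)NC(=O)Nc2ccccc2C(=O)/C=C/c2cccc(F)c2)cc1` gives 4.13 ug/mL, and compound 3 `C=CCOc1ccc(/C=C/C(=O)c2ccccc2NC(=O)NS(=O)(=O)c2ccc(C)cc2)cc1` gives 6.11 ug/mL. Compound 3 stands with compound 2 as its nearest neighbour, since the step of a 1.5-fold higher number from compound 2 to compound 3 (0.17 log units; within the scatter), while the step of a 4.1-fold lower number from compound 1 to compound 3 (0.61 log units; beyond the scatter) sets it clearly apart from compound 1. The step of a 6.1-fold lower number from compound 1 to compound 2 (0.78 log units; beyond the scatter) is of similar size.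

Compound 4 `Cc1ccc(S(=O)(=O)NC(=O)Nc2ccccc2C(=O)/C=C/c2ccc[nH]2)cc1` differs from compound 3 in one place: 1H-pyrrol-2-yl in place of 4-(allyloxy)phenyl on a double-bonded chain carbon bound to a double-bonded chain carbon. Within the data shown here, none of the measured steps exchanges the whole ring on the chain for a different ring; the two steps from compound 1 add a small group to that ring and both lower the number modestly, and the step from compound 2 to compound 3 swaps one substituted ring for another without leaving the scatter. These steps show that this end of the chain matters, but they give no direct guide for a five-membered ring with a hydrogen-bond donor. The expectation for compound 4 is therefore a number near that of compound 3 with a wide range, and the estimated step of a 1.6-fold higher number from compound 3 to compound 4 (0.21 log units; within the scatter) is taken as small. Compound 4 is estimated at 10 ug/mL, between 3 ug/mL and 35 ug/mL.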

Compound 4, concentration for half-maximal effect: 32.1 ug/mL
The estimate for compound 4 lay 3.2-fold (0.51 log units) below the measured number; low and high end bracket the measured number.
By their numbers in this assay, from the lowest: compounds 2 and 3 (each within the scatter of the next); then compounds 1 and 4 (each within the scatter of the next).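

In this assay, replacing the whole ring on this chain carbon can shift the number beyond the scatter: 1H-pyrrol-2-yl in place of 4-(allyloxy)phenyl gives a clear rise (a 5.3-fold higher number from compound 3 to compound 4 (0.72 log units; beyond the scatter)), and 1H-pyrrol-2-yl in place of 3-fluorophenyl gives one of similar size (a 7.8-fold higher number from compound 2 to compound 4 (0.89 log units; beyond the scatter)). Against the unsubstituted phenyl ring, the same five-membered ring makes no clear difference (a 1.3-fold higher number from compound 1 to compound 4 (0.11 log units; within the scatter)), so among these four compounds the lower numbers occur only with a fluoro or allyloxy group on a phenyl ring, and changing phenyl to 1H-pyrrol-2-yl does not reproduce them. The compounds shown carry no measurement that explains why these rings differ, and the hydrogen-bond donor that enters cannot be separated from the smaller ring that comes with it.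

A furan or thiophene ring on this carbon, or a pyrrole with a methyl group on its nitrogen, would help to separate those two features. A fluoro or allyloxy group on the pyrrole ring itself would test whether the lowering seen on phenyl carries over to the five-membered ring.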